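Ester to acid: working notes on compounds 1 and 3

The source may report more compounds than this note shows. Statements on the series, on what has been measured and on what is new or still open speak of the compounds shown alone.

Measured so far:
compound 1 `C=CCN(CCC(=O)OCC)C(=O)/C(C)=C/c1ccc(C(=O)Oc2ccc(C(=N)N)cc2)cc1` — 1 h
compound 2 `CCOC(=O)CN(C(=O)/C(C)=C/c1ccc(C(=O)Oc2ccc(C(=N)N)cc2)cc1)C1CCCC1` — > 1 h

In an in vitro ADME assay on the whole organism (small intestine) for pharmacokinetics, with Rattus norvegicus as the target (a lower number here means that the compound disappears faster, a higher number that the compound lasts longer), compound 1 gives 1 h. For compound 2 the result in this assay is a limit of the assay, > 1 h, not a number; that is the limit of > 1 h in this assay, at which 1 of the 2 values shown sits. Within the data shown here, with only one numeric value in the set, compound 1 cannot be placed relative to any other compound, and no step between measured compounds is available.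

The unmeasured compound 3 `C=CCN(CCC(=O)O)C(=O)/C(C)=C/c1ccc(C(=O)Oc2ccc(C(=N)N)cc2)cc1` differs from compound 1 by hydrogen in place of ethyl on an oxygen next to a carbonyl group, the ethoxycarbonyl of compound 1 becoming carboxy. No comparable change has been measured in this series, so no step size can be read from the data.

The step of a 3.0-fold higher number from compound 1 to compound 3 (0.48 log units; beyond the scatter) is nevertheless expected to be upward and beyond the scatter. Compound 3 is estimated to reach 3 h in this assay, with a range from 1 h to 8 h, and a real chance that the assay again reports only a limit.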

Compound 3, half-life: > 1 h
Compound 3 gave a limit, no number; the forecaster's own chance of this, stated with the estimate: 55%; the middle value lies beyond the limit too.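

In this assay compound 3 gives > 1 h, which is a limit of the assay and not a number. Hydrogen in place of ethyl on an oxygen next to a carbonyl group, the ethoxycarbonyl becoming carboxy, is the first change in this series that can be followed between two measured compounds, and it gives a number no lower from compound 1 to compound 3 (the limit leaves the size open). This step fixes only a direction, with carboxy on this chain giving no lower a number than ethoxycarbonyl, and the limit now covers most of the set: the limit of > 1 h in this assay, at which 2 of the 3 values shown sit.

The size of the step cannot be read, and neither compound 2 nor compound 3 offers a number that could place compound 1 within the series. Going by these compounds, it also remains open whether a methyl ester, a longer ester chain or a primary amide in place of the ethoxycarbonyl of compound 1 would give a readable number in this assay, or whether the same change from ethoxycarbonyl to carboxy would read the same way on the core of compound 2.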